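Chain growth from compound 2 to compound 3

The source may hold more compounds than are shown below. What is called first, only, known or untested is meant among the compounds shown, and "the series" means these compounds.

Values in an ADME assay on Vero cells (Chlorocebus sabaeus) for cytotoxicity; a lower number here means a stronger inhibitor, a higher number a weaker inhibitor:
- compound 1 `CCCCCCC(=O)c1cc(O)c(O)c(O)c1`: > 1000 nM (a limit)
- compound 2 `CCCCCCCCCCC(=O)c1cc(O)c(O)c(O)c1`: > 1000 nM (a limit)
- compound 3 `CCCCCCCCCCCCC(=O)c1cc(O)c(O)c(O)c1`: not yet measured

Compound 2 has no number in this assay, only the limit > 1000 nM. Going by the values given here, the same holds for the whole series so far: the limit of > 1000 nM in this assay, at which 2 of the 2 values shown sit.

The next change is ethyl in place of hydrogen on a saturated chain carbon, ten or more bonds along the chain from a carbonyl carbon. Among the compounds with values here, it extends the saturated chain further, as the one measured step did. That step is a step that the two limits leave unreadable from compound 1 to compound 2, so it offers no size to carry over and no direction to follow. No readable step is therefore expected in this assay, and compound 3 will most likely be reported as a limit again. The estimated step is a step that the limit leaves unreadable from compound 2 to compound 3, and its direction is uncertain. For compound 3 the expected value is 3000 nM, with an estimated range of 1200 nM to 15000 nM.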

Compound 3, half-maximal inhibitory concentration: > 1000 nM
Compound 3 gave a limit, no number (the forecaster's own chance of this, stated with the estimate: 70%); the middle value lies beyond the limit too.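

The steps among compound 1, compound 2 and compound 3 in this assay cannot be read, since each result is a limit and not a number: the limit of > 1000 nM in this assay, at which 3 of the 3 values shown sit.

The compounds shown leave open whether lengthening the saturated chain changes the value in this assay at all, and in which direction.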